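Same Fluorine Swap Tried on a Longer Side Chain

The source may report more compounds than this note shows. Statements on the series, on what has been measured and on what is new or still open speak of the compounds shown alone.

Compound 1 `CC(C)=CCC1Cc2c(OC(=O)Nc3ccc(F)cc3F)cc(=O)n(CCCO)c2CC1(C)C` and compound 2 `CC(C)=CCC1Cc2c(OC(=O)Nc3ccc(F)c(F)c3)cc(=O)n(CCCO)c2CC1(C)C` share one core and differ only in the aryl group of the carbamate, the difference being (3,4-difluorophenyl in place of 2,4-difluorophenyl on an amide-type nitrogen). In a functional assay on PANC-1 cells (Homo sapiens) for inhibition, read by MTT assay, with a stated time of 24 h, tested at 10 uM (on this read-out lower numbers stand for less inhibition and higher numbers for more inhibition at the one concentration tested (going by the name of the read-out)), compound 1 gives 69.7%, while compound 2 gives 76.7%, so that a number 7 percentage points higher from compound 1 to compound 2 (within the scatter). Compound 3 `CC(C)=CCC/C(C)=C/CC1Cc2c(OC(=O)Nc3ccc(F)cc3F)cc(=O)n(CCCO)c2CC1(C)C` keeps the aryl group of compound 1 but carries a longer chain on the core: 3-methylbut-2-en-1-yl in place of hydrogen on a saturated chain carbon bound to a double-bonded chain carbon. In this assay compound 3 gives 33.7%, the lowest of the three numbers, and a number 36 percentage points lower from compound 1 to compound 3 (beyond the scatter). Compound 4 `CC(C)=CCC/C(C)=C/CC1Cc2c(OC(=O)Nc3ccc(F)c(F)c3)cc(=O)n(CCCO)c2CC1(C)C` stands to compound 3 as compound 2 stands to compound 1, the change being (3,4-difluorophenyl in place of 2,4-difluorophenyl on an amide-type nitrogen); the place of the change is described in the same words in both pairs, so it is the same change set on the core of compound 3. Because the earlier step of a number 7 percentage points higher from compound 1 to compound 2 (within the scatter) lay within the scatter, a similarly small step is expected here: a number 6.3 percentage points higher from compound 3 to compound 4 (within the scatter). Compound 4 is therefore estimated at 40%, with a likely range from 25% to 56%.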

Compound 4, a percentage reported as inhibition, at one concentration (the size of the read-out at that concentration, not a potency): 43.7%
For compound 4 the middle estimate is 3.7 percentage points below the measured one, within the range that was stated.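

In this assay, 3,4-difluorophenyl in place of 2,4-difluorophenyl on the amide-type nitrogen gives a number 10 percentage points higher from compound 3 to compound 4 (within the scatter), and this step does not differ from the one seen on the other core: the same change on two cores in this assay, a number 7 percentage points higher (within the scatter) from compound 1 to compound 2 and a number 10 percentage points higher (within the scatter) from compound 3 to compound 4, 3 percentage points apart, within the scatter of two such steps Adding 3-methylbut-2-en-1-yl to the chain gives a number 33 percentage points lower from compound 2 to compound 4 (beyond the scatter), and this large drop also carries over with the other aryl group in place: the same change on two cores in this assay, a number 36 percentage points lower (beyond the scatter) from compound 1 to compound 3 and a number 33 percentage points lower (beyond the scatter) from compound 2 to compound 4, 3 percentage points apart, within the scatter of two such steps Within these four compounds the two changes therefore add up consistently, but the aryl step stays within the scatter on both cores, so the data do not show that the swap itself alters the number, and two cores cannot establish a rule for the wider series.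

The compounds shown leave open whether the same holds for a plain phenyl group or a chlorophenyl group on the amide-type nitrogen. They also leave open how a still longer chain on the core, or an amine or carboxylic acid in place of the hydroxyl group, would behave.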